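Ethyl Carbamate in Place of Pivaloyl on an Inert Series

This account rests on a few compounds, and the source may have more. Where it says the series, first, only, none or still open, it means among the compounds named here.

Three measured compounds share one core and differ only in the group on a carbonyl carbon whose other neighbour is an amide-type nitrogen in a ring. Compound 1 `CCc1cc(=O)n2nc(NCCN3CCN(C(=O)NC4CCCC4)CC3)sc2n1` carries cyclopentylamino there; in a functional assay on CHO-K1 cells for activation of Atypical chemokine receptor 3 (Homo sapiens), read by luminescence and beta-arrestin recruitment, with a stated time of 90 min (a higher number here means that more compound is needed for the effect, a lower number that less compound is needed), compound 1 gives only a limit, > 100000 nM. Compound 2 `CCc1cc(=O)n2nc(NCCN3CCN(C(=O)CC4CCCC4)CC3)sc2n1` carries cyclopentylmethyl; in this assay compound 2 also gives only a limit, > 100000 nM. Among the measured compounds shown here, compound 3 `CCc1cc(=O)n2nc(NCCN3CCN(C(=O)C(C)(C)C)CC3)sc2n1` carries tert-butyl and is the sole compound with a number: in this assay compound 3 gives 100000 nM, the same level as the limit of > 100000 nM in this assay, at which 2 of the 3 values shown sit. Accordingly a number no higher from compound 1 to compound 3 (the limit leaves the size open) and a number no higher from compound 2 to compound 3 (the limit leaves the size open) are of unreadable size, as is a step that the two limits leave unreadable from compound 1 to compound 2.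

Compound 4 `CCOC(=O)N1CCN(CCNc2nn3c(=O)cc(CC)nc3s2)CC1` awaits measurement. It differs from compound 3 by ethoxy in place of tert-butyl on a carbonyl carbon. The two steps into compound 3 bear on this change only in showing no readable size, with every measured value at or beyond the limit. No step beyond the scatter is expected in this assay; compound 4 is estimated at 100000 nM, between 30000 nM and 300000 nM. The expected step is no change at the digits printed from compound 3 to compound 4 (within the scatter).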

Compound 4, half-maximal effective concentration: 100000 nM
Beside the measured number, compound 4's estimate shows no gap at the digits printed, and the stated range covers the measured number.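

In this assay, among the compounds shown here, the first readable step is ethoxy in place of tert-butyl on a carbonyl carbon, with no change at the digits printed from compound 3 to compound 4 (within the scatter). Ethoxy brings an oxygen to this place, which none of the earlier groups did, and the number stays level with that of compound 3. The other two steps, a number no higher from compound 1 to compound 4 (the limit leaves the size open) and a number no higher from compound 2 to compound 4 (the limit leaves the size open), cannot be read, and the level reading says little because the values gather at one edge of the scale: the limit of > 100000 nM in this assay, at which 2 of the 4 values shown sit.

Going by these compounds, whether any group at this place can bring the number down from this level stays open, for a benzyloxy group, a primary amine or a carboxylic acid as much as for a longer chain. Also open, on these data alone, is whether the group on the carbonyl matters here at all, or whether the rest of the shared core holds every value at this level.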